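Fluoro for Chloro on the Aryl Ring of Compound 3

The compounds below may be only part of what the source reports. "The series", "measured", "known", "first", "only" and "open" are said of these compounds alone.

Compound 3 `Cn1c(=O)c(=O)n(C2CCCC2)c2nc(N/N=C/c3ccc(F)cc3Cl)ncc21` gives 15200 nM in a functional assay on PC-3 cells (Homo sapiens) for antiproliferative activity, read by MTT assay; a higher number here means a weaker inhibitor, a lower number a stronger inhibitor. It stands second highest of three numbers: compound 2 `Cn1c(=O)c(=O)n(C2CCCC2)c2nc(N/N=C/c3ccc(S(C)(=O)=O)cc3)ncc21` gives 26600 nM and compound 1 `Cn1c(=O)c(=O)n(C2CCCC2)c2nc(N/N=C/c3ccc(F)c(Cl)c3)ncc21` gives 8550 nM, and the steps of a 1.8-fold lower number from compound 2 to compound 3 (0.24 log units; within the scatter) and a 1.8-fold higher number from compound 1 to compound 3 (0.25 log units; within the scatter) are both within the scatter. Compound 4 `Cn1c(=O)c(=O)n(C2CCCC2)c2nc(N/N=C/c3ccc(F)cc3F)ncc21` differs from compound 3 by fluoro in place of chloro on an aromatic carbon. For the measured compounds named here, no measured step exchanges one halogen for another; the nearest comparisons keep the same halogens in different places, as in a 1.8-fold higher number from compound 1 to compound 3 (0.25 log units; within the scatter), or replace the whole aryl group, as in a 3.1-fold higher number from compound 1 to compound 2 (0.49 log units; beyond the scatter), and only the latter moved beyond the scatter. Compound 4 is therefore expected to show a step of a 1.0-fold lower number from compound 3 to compound 4 (0.01 log units; within the scatter), not beyond the scatter. For compound 4 the estimate is 15000 nM, within 6000 nM to 38000 nM.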

Compound 4, half-maximal inhibitory concentration: 13200 nM
The estimate for compound 4 lay 1.1-fold (0.06 log units) above the measured number, and the stated range covers the measured number.
By their numbers in this assay, from the lowest: compounds 1, 4, 3 and 2 (each within the scatter of the next, the first and the last beyond it).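

For the compounds shown here, the first exchange of one halogen for another at this position, fluoro in place of chloro on an aromatic carbon ortho to a large group, stays within the scatter in this assay (a 1.2-fold lower number from compound 3 to compound 4 (0.06 log units; within the scatter)). The 2,4-difluorophenyl compound also lies within the scatter of the two other aryl compounds (a 2.0-fold lower number from compound 2 to compound 4 (0.30 log units; within the scatter)) and (a 1.5-fold higher number from compound 1 to compound 4 (0.19 log units; within the scatter)). No evidence on any cause accompanies these numbers.

From the compounds shown here alone, whether an amine or a carboxylic acid at this position would give a step beyond the scatter remains open.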